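Ring halide variation in a calpain-1 inhibitor series

This account rests on a few compounds, and the source may have more. Where it says the series, first, only, none or still open, it means among the compounds named here.

Measured so far in an assay on isolated protein for inhibition of Calpain-1 catalytic subunit (Sus scrofa), read by FRET; on this read-out higher numbers stand for weaker inhibition and lower numbers for stronger inhibition:
compound 1 `O=C(O)/C(S)=C/c1c[nH]c2ccc(F)cc12`: 800 nM
compound 2 `O=C(O)/C(S)=C/c1c[nH]c2ccc(I)cc12`: 100 nM
compound 3 `O=C(O)/C(S)=C/c1c[nH]c2ccc(Br)cc12`: 6 nM

Compound 3 gives the lowest number of the three and is the most potent of the measured set; its nearest neighbour is compound 2 and its furthest is compound 1, both separated from it by more than the scatter. Compound 4 `O=C(O)/C(S)=C/c1c[nH]c2ccc(Cl)cc12` differs from compound 3 by chloro in place of bromo on an aromatic carbon.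

For the measured compounds named here, three measured steps bear on this change, each an exchange of one ring halide for another at the same place: a 130-fold lower number from compound 1 to compound 3 (2.12 log units; beyond the scatter), a 17-fold lower number from compound 2 to compound 3 (1.22 log units; beyond the scatter) and an 8.0-fold lower number from compound 1 to compound 2 (0.90 log units; beyond the scatter). Going by the values given here, none of them involves chloro, so the step to compound 4 has no direct precedent. What the measured steps show is that every halide exchange at this place moved this assay number beyond the scatter, and that bromo gave the lowest number against both fluoro and iodo. Among the compounds with values here, on that basis the loss of bromo is expected to raise the number rather than lower it, with an expected step of a 5.0-fold higher number from compound 3 to compound 4 (0.70 log units; beyond the scatter), of uncertain size given that no chloro analogue has been run. The estimate for compound 4 in this assay is 30 nM, with a range from 6 nM to 150 nM.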

Compound 4, half-maximal inhibitory concentration: 250 nM
The estimate for compound 4 lay 8.3-fold (0.92 log units) below the measured number; the whole stated range lies below it.
By their numbers in this assay, from the lowest: compound 3; then compound 2; then compound 4; then compound 1.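

In this assay the exchange of bromo for chloro gives a 42-fold higher number from compound 3 to compound 4 (1.62 log units; beyond the scatter), which shows that the low number at this place does not extend to the next halide tried and that a single halide exchange here can produce a large step. Compound 4 instead falls among the other halides, with a 2.5-fold higher number from compound 2 to compound 4 (0.40 log units; beyond the scatter) and a 3.2-fold lower number from compound 1 to compound 4 (0.51 log units; beyond the scatter); both steps are modest but beyond the scatter, giving the order bromo, iodo, chloro, fluoro from the lowest number to the highest, with bromo standing well apart from the other three and iodo in compound 2 lying closer to it than chloro does. Nothing available accounts for why bromo stands apart from the other halides at this place.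

The compounds shown leave open whether any group other than a halide at this place, such as methyl, methoxy or nitrile, could match compound 3 at 6 nM in this assay. They also leave open whether the order of the halides would hold if the carboxylic acid of the shared core gave way to an amide.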